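Amide nitrogen aryl change: compound 3 to compound 4

The source may hold more compounds than are shown below. What is called first, only, known or untested is meant among the compounds shown, and "the series" means these compounds.

Three measured compounds share one core and differ only at an amide-type nitrogen. Compound 1 `CNC(=O)c1nc(-c2cc(OC)c(OC)c(OC)c2)n(-c2ccc(OC)cc2)n1` carries a methyl there; in a functional assay on the whole organism for inhibition, with Rattus norvegicus as the target, read by paw edema, with stated times of 30 min and 5 h, at a dose of 0.28 mmol/kg by the oral route (on this read-out lower numbers stand for less inhibition and higher numbers for more inhibition at the one dose given (going by the name of the read-out)), compound 1 gives 50%. Compound 2 `COc1ccc(-n2nc(C(=O)Nc3ccccc3OC)nc2-c2cc(OC)c(OC)c(OC)c2)cc1` carries a 2-methoxyphenyl, and in this assay compound 2 gives 10%. Compound 3 `COc1ccc(-n2nc(C(=O)Nc3cccc(F)c3)nc2-c2cc(OC)c(OC)c(OC)c2)cc1` carries a 3-fluorophenyl; in this assay compound 3 gives 53%, the highest of the three numbers, though its gap to compound 1 is within the scatter. Only compound 2 lies clearly lower: a number 43 percentage points higher from compound 2 to compound 3 (beyond the scatter).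

Compound 4 `COc1ccc(-n2nc(C(=O)Nc3ccc(C(F)(F)F)cc3)nc2-c2cc(OC)c(OC)c(OC)c2)cc1` differs from compound 3 by 4-(trifluoromethyl)phenyl in place of 3-fluorophenyl on an amide-type nitrogen. Among the compounds with values here, no measured step covers this pair. The steps at the same nitrogen were a number 40 percentage points lower from compound 1 to compound 2 (beyond the scatter), a number 3 percentage points higher from compound 1 to compound 3 (within the scatter) and a number 43 percentage points higher from compound 2 to compound 3 (beyond the scatter): one aryl group gave a number within the scatter of the methyl compound, the other lowered it strongly, so the aryl identity matters but its direction cannot be read from two examples. A further aryl with a single substituent may land near compound 3 or fall back toward compound 2, so the middle ground is taken. Compound 4 is expected to give 38% in this assay, with a range from 15% to 58%. That estimate means a step of a number 15 percentage points lower from compound 3 to compound 4 (beyond the scatter).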

Compound 4, a percentage reported as inhibition, in the whole organism at one dose (the size of the read-out at that dose, not a potency): 50%
Beside the measured number, compound 4's estimate is 12 percentage points below it, within the range that was stated.
By their numbers in this assay, from the lowest: compound 2; then compounds 1, 4 and 3 (each within the scatter of the next).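

In this assay, the 4-(trifluoromethyl)phenyl group on the amide-type nitrogen gives no separation from 3-fluorophenyl (a number 3 percentage points lower from compound 3 to compound 4 (within the scatter)) or from methyl (no change at the digits printed from compound 1 to compound 4 (within the scatter)), while it stands well clear of 2-methoxyphenyl (a number 40 percentage points higher from compound 2 to compound 4 (beyond the scatter)). A second aryl group with a single substituent therefore matches the methyl compound, so among these four compounds an aryl group at this nitrogen does not by itself bring the number down, and compound 2 is the one that goes against this. Nothing measured here bears on why compound 2 lies apart.

As far as these compounds go, whether the low number of compound 2 belongs to the methoxy group itself or to its place on the ring stays open. Also open, from the compounds shown here alone, is how plain phenyl, benzyl, or an aryl group carrying an amine or a carboxylic acid would read at this nitrogen.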